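Smaller Amine Substituent in a Series Stuck at the Limit

A few compounds are considered here, and "the series" means these few. Any claim that something is new, unique, unknown or untested is made for them only; others in the source may bear on it.

Three measured compounds share one core. Compound 1 `CN(C[C@H]1Cc2c(cccc2N2CCNC(C)(C)C2)CN1)[C@H]1CCCc2cccnc21` and compound 2 `CN(C[C@H]1Cc2c(cccc2N2CCN3CCC[C@H]3C2)CN1)[C@H]1CCCc2cccnc21` differ in a ring group on an aromatic carbon, while compound 3 `FC1(F)CCC(CN(C[C@H]2Cc3c(cccc3N3CCNCC3)CN2)[C@H]2CCCc3cccnc32)CC1` carries a (4,4-difluorocyclohexyl)methyl group on an amine nitrogen. In a functional assay on CCRF-CEM cells for agonist activity at C-X-C chemokine receptor type 4 (Homo sapiens), read by calcium flux, with a stated time of 25 min (on this read-out lower numbers stand for an effect already at smaller amounts and higher numbers for an effect only at larger amounts of compound), compound 1 gives > 30000 nM, which is a limit of the assay and not a number. In this assay compound 2 likewise gives only the limit > 30000 nM. Compound 3 also stands only at the limit, with > 30000 nM. The step that the two limits leave unreadable from compound 1 to compound 2 therefore cannot be read, and the limit of > 30000 nM in this assay, at which 3 of the 3 values shown sit, is all the measurements show. Compound 4 `CC(C)N(C[C@H]1Cc2c(cccc2N2CCNCC2)CN1)[C@H]1CCCc2cccnc21` differs from compound 3 by isopropyl in place of (4,4-difluorocyclohexyl)methyl on an amine nitrogen. Going by the values given here, no measured step bears on this change, so compound 4 is expected to stay at the limit, estimated at 30000 nM (range 10000 nM to 100000 nM), an expected step of a number no higher from compound 3 to compound 4 (the limit leaves the size open) within the scatter.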

Compound 4, half-maximal effective concentration: > 30000 nM
Compound 4: only a limit was reported (the forecaster's own chance of this, stated with the estimate: 85%); the middle value lies on the limit itself.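

Compound 4 stays at the assay limit, as compound 3 does, so the step between them cannot be read: the limit of > 30000 nM in this assay, at which 4 of the 4 values shown sit. What the compounds shown leave open is whether any change to the shared core gives a real number in this assay rather than a limit.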